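Removing the ring methyl from compound 1

The source may report more compounds than this note shows. Statements on the series, on what has been measured and on what is new or still open speak of the compounds shown alone.

Going by the values given here, compound 1 `CC(=O)N1CCC(C(=O)Nc2sc3c(c2C(=O)NC2CC2)CCC(C)C3)CC1` gives 2500 nM in an assay for displacement of a labelled ligand from DNA repair protein REV1 (Homo sapiens), read by fluorescence polarization, with a stated time of 1 h (a lower number here means a stronger inhibitor, a higher number a weaker inhibitor), the lowest of the two numbers measured so far; the nearest is compound 2 `CC(=O)N1CCC(C(=O)Nc2sc3c(c2C(N)=O)CCC(C)C3)CC1`, which in this assay gives 13200 nM. Among the compounds with values here, the only step among the measured compounds, hydrogen in place of cyclopropyl on an amide-type nitrogen, is a 5.3-fold higher number from compound 1 to compound 2 (0.72 log units; beyond the scatter).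

Compound 3 `CC(=O)N1CCC(C(=O)Nc2sc3c(c2C(=O)NC2CC2)CCCC3)CC1` differs from compound 1 at another place: hydrogen in place of methyl on a saturated ring carbon. Within the data shown here, no measured pair varies this position, so the step from compound 1 to compound 2 in this assay does not bear on it directly; it shows only that the shared core answers to change elsewhere. With nothing to anchor the contribution of the methyl, no step beyond the scatter is expected in this assay for compound 3 in either direction, and the range is left wide. The step expected from compound 1 to compound 3 is a 1.3-fold higher number from compound 1 to compound 3 (0.11 log units; within the scatter). Compound 3 is therefore estimated at 3200 nM in this assay, with a range from 1000 nM to 10000 nM.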

Compound 3, half-maximal inhibitory concentration: 21500 nM
For compound 3 the middle estimate is 6.7-fold (0.83 log units) below the measured one; the whole stated range lies below it.
By their numbers in this assay, from the lowest: compound 1; then compounds 2 and 3 (each within the scatter of the next).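

In this assay, the methyl on a saturated ring carbon proves to matter: an 8.6-fold higher number from compound 1 to compound 3 (0.93 log units; beyond the scatter), a step beyond the scatter for a change that removes only one carbon and no hydrogen-bond donor or acceptor. This position therefore answers to change, as does the amide-type nitrogen, where the step is a 5.3-fold higher number from compound 1 to compound 2 (0.72 log units; beyond the scatter), and both single changes shown raise the number. The data at hand offer nothing that explains the effect of the methyl.

Only methyl and hydrogen are shown on this ring carbon, so it remains open whether an ethyl, a hydroxyl or a fluorine there would give a lower number than methyl, or whether methyl is already the better end of the range. It also remains open whether the step seen for the methyl would keep its size with hydrogen instead of cyclopropyl on the amide-type nitrogen, since the two changes are shown only apart and any dependence of one on the other cannot be read.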